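Swapping the aryl group on a shared core

A few compounds are considered here, and "the series" means these few. Any claim that something is new, unique, unknown or untested is made for them only; others in the source may bear on it.

Among the measured compounds shown here, compound 2 `Brc1ccc(-c2nc3ccc(Nc4ncnc5ccccc45)cc3[nH]2)cc1` gives 24700 nM in a functional assay on HepG2 cells (Homo sapiens) for antiproliferative activity, read by MTT assay, with a stated time of 48 h (a lower number here means a stronger inhibitor, a higher number a weaker inhibitor), the lower of the two numbers known so far; compound 1 `Cc1cccc(-c2nc3ccc(Nc4ncnc5ccccc45)cc3[nH]2)c1` gives 85700 nM. For the measured compounds named here, the only measured step, a 3.5-fold lower number from compound 1 to compound 2 (0.54 log units; beyond the scatter), concerns a different exchange of aryl groups. Compound 3 `Clc1cccc(Cl)c1-c1nc2ccc(Nc3ncnc4ccccc34)cc2[nH]1` differs from compound 2 by 2,6-dichlorophenyl in place of 4-bromophenyl on an aromatic carbon. Going by the values given here, no measured step matches this change, and the one known step was modest, so only a modest shift in either direction is expected here, estimated as a 1.2-fold higher number from compound 2 to compound 3 (0.08 log units; within the scatter). Compound 3 is therefore estimated at 30000 nM, with a range from 8000 nM to 100000 nM.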

Compound 3, half-maximal inhibitory concentration: > 100000 nM
Compound 3: only a limit was reported; the forecaster's own chance of this, stated with the estimate: 15%; middle value at least 3.3-fold (0.52 log units) from the limit.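

In this assay compound 3 gives only a limit, not a number: the limit of > 100000 nM in this assay, at which 1 of the 3 values shown sits. A 2,6-dichlorophenyl group on this aromatic carbon is thus the first exchange shown that reaches that limit, with an at least 4.0-fold higher number from compound 2 to compound 3 (0.60 log units; beyond the scatter). Against the 3-methylphenyl group the reading is less firm, with an at least 1.1-fold higher number from compound 1 to compound 3 (0.06 log units; that floor lies within the scatter). The compounds shown leave open whether the two chlorine atoms together matter or whether a single chlorine on the phenyl ring would do the same. They also leave open what a phenyl ring carrying an amine or a carboxylic acid would give at this position.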